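The compounds below may be only part of what the source reports. "The series", "measured", "known", "first", "only" and "open" are said of these compounds alone.

Measured in a functional assay on L1210 cells (Mus musculus) for inhibition, with a stated time of 48 h; on this read-out higher numbers stand for weaker inhibition and lower numbers for stronger inhibition:
- Compound 1 `CCCNCCCNCCCNCCC`: > 100000 nM
- Compound 2 `CCNCCCNCCCCN`: > 100000 nM

Neither entry is a true number. Compound 2 gives > 100000 nM, which is a limit of the assay. It shares this position with compound 1, as the evidence so far shows: the limit of > 100000 nM in this assay, at which 2 of the 2 values shown sit.

Compound 3 `CCCNCCCNCCCCN` has not yet been measured. It differs from compound 2 by a single change: methyl in place of hydrogen on a saturated chain carbon, two bonds along the chain from an amine nitrogen.

Among the compounds with values here, no measured pair shows what this change does in this assay. With no number yet on either side, no step beyond the scatter is expected, and the most likely report is again a limit. The expected step is a number no higher from compound 2 to compound 3 (the limit leaves the size open). For compound 3 the estimated value is 100000 nM, with an expected range of 40000 nM to 250000 nM.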

Compound 3, half-maximal inhibitory concentration: > 100000 nM
Compound 3: only a limit was reported; the forecaster's own chance of this, stated with the estimate: 75%; the middle value lies on the limit itself.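

In this assay compound 3 gives > 100000 nM, which is a limit of the assay and not a number. Within the data shown here, compound 1 and compound 2 are also reported only as limits, so no step to compound 3 can be read. On these data alone, whether methyl in place of hydrogen changes inhibition at all stays open.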